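This account rests on a few compounds, and the source may have more. Where it says the series, first, only, none or still open, it means among the compounds named here.

Compound 1 `CC(NC(=O)c1ccc(C(=N)N)cc1)C(C)(C)C(=O)N1CCC(CC(=O)O)CC1`: 0.883 h
Compound 2 `CCC(NC(=O)c1ccc(C(=N)N)cc1)C(C)(C)C(=O)N1CCC(CC(=O)O)CC1`: 1.3 h
Compound 3 `CCCCC(NC(=O)c1ccc(C(=N)N)cc1)C(C)(C)C(=O)N1CCC(CC(=O)O)CC1`: 1.03 h

In an in vivo ADME assay on the whole organism (Cavia porcellus) (on this read-out lower numbers stand for a shorter-lived compound and higher numbers for a longer-lived compound), compound 3 gives 1.03 h, which places it within the scatter of the other two compounds. The steps that reach it are a 1.2-fold higher number from compound 1 to compound 3 (0.07 log units; within the scatter) and a 1.3-fold lower number from compound 2 to compound 3 (0.10 log units; within the scatter). The next compound to be measured is compound 4 `CC(C)(C(=O)N1CCC(CC(=O)O)CC1)C(CCc1ccccc1)NC(=O)c1ccc(C(=N)N)cc1`, and the change leading to it is phenyl in place of ethyl on a saturated chain carbon, three bonds along the chain from an amide-type nitrogen. Cut one bond further out, the same change reads butyl to phenethyl.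

The second of those steps, an ethyl in place of hydrogen, falls at this same place on the chain and bears most directly on the change. The other two measured steps, the first of those above and a 1.5-fold higher number from compound 1 to compound 2 (0.17 log units; within the scatter), concern the same chain, and none of the three goes beyond the scatter. For the measured compounds named here, no measured compound carries a ring on this chain, so the data cover that part of the change only indirectly.

No shift beyond the scatter is therefore expected, and the expected result is a 1.0-fold lower number from compound 3 to compound 4 (0.01 log units; within the scatter). The estimate for compound 4 is 1 h, with an expected range from 0.5 h to 2 h.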

Compound 4, half-life: 0.767 h
For compound 4 the middle estimate is 1.3-fold (0.12 log units) above the measured one, within the range that was stated.
By their numbers in this assay, from the lowest: compounds 4, 1, 3 and 2 (each within the scatter of the next).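

In this assay, for the compounds shown here, an aromatic ring stands on this chain for the first time, and phenyl in place of ethyl, on a saturated chain carbon three bonds along the chain from an amide-type nitrogen, gives a 1.3-fold lower number from compound 3 to compound 4 (0.13 log units; within the scatter) as its step. The two longer comparisons read alike, with a 1.7-fold lower number from compound 2 to compound 4 (0.23 log units; within the scatter) for phenyl in place of hydrogen and a 1.2-fold lower number from compound 1 to compound 4 (0.06 log units; within the scatter) for benzyl in place of hydrogen, so among these four compounds the ring brings no step beyond the scatter. No measurement at hand offers an explanation for these half-lives.

From the compounds shown here alone, whether a phenyl ring carrying an amine or a carboxylic acid would stay within the scatter remains open. So does the outcome for a cyclohexyl ring or a longer chain at this place.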